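Swapping Cyclopentyl for Phenyl on the Ring Nitrogen

The compounds below may be only part of what the source reports. "The series", "measured", "known", "first", "only" and "open" are said of these compounds alone.

Compound 1, `Cc1cc2c(c(Oc3cccc(NS(=O)(=O)c4ccc(Cl)cc4)c3)n1)C(=O)NC2=O`: in a functional assay on HEK293 cells for agonist activity at Glucose-dependent insulinotropic receptor (Homo sapiens), read by cAMP accumulation, with a stated time of 30 min (a higher number here means that more compound is needed for the effect, a lower number that less compound is needed), compound 1 gives 121 nM.
Compound 2, `Cc1cc2c(c(Oc3cccc(NS(=O)(=O)c4ccc(Cl)cc4)c3)n1)C(=O)N(C)C2=O`: compound 2 gives 23 nM.
Compound 3, `Cc1cc2c(c(Oc3cccc(NS(=O)(=O)c4ccc(Cl)cc4)c3)n1)C(=O)N(C1CCCC1)C2=O`: compound 3 gives 69 nM.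

All three share one core and differ only in the group on an amide-type nitrogen in a ring. Compound 3 stands second highest of the three numbers; its nearest neighbour is compound 1, with a 1.8-fold lower number from compound 1 to compound 3 (0.24 log units; within the scatter), while a 3.0-fold higher number from compound 2 to compound 3 (0.48 log units; beyond the scatter) lies beyond the scatter. Compound 4, `Cc1cc2c(c(Oc3cccc(NS(=O)(=O)c4ccc(Cl)cc4)c3)n1)C(=O)N(c1ccccc1)C2=O`, carries phenyl in place of cyclopentyl on an amide-type nitrogen in a ring. Among the measured compounds shown here, no measured step exchanges one ring for another. For the measured compounds named here, the steps that bear on it are a 3.0-fold higher number from compound 2 to compound 3 (0.48 log units; beyond the scatter), where a larger group gave a higher number than methyl, and a 1.8-fold lower number from compound 1 to compound 3 (0.24 log units; within the scatter). With rings of similar count, the expected step of a 1.2-fold higher number from compound 3 to compound 4 (0.06 log units; within the scatter) is small. Compound 4 is estimated at 80 nM, ranging from 25 nM to 250 nM.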

Compound 4, half-maximal effective concentration: 299 nM
Estimate against measurement, compound 4: 3.7-fold (0.57 log units) below; measured number outside the range, above it.
By their numbers in this assay, from the lowest: compound 2; then compounds 3 and 1 (each within the scatter of the next); then compound 4.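

Phenyl and cyclopentyl are both single carbon rings, yet in this assay exchanging one for the other gives a 4.3-fold higher number from compound 3 to compound 4 (0.64 log units; beyond the scatter), so the kind of ring on this nitrogen matters, not only its presence. Phenyl is the only group here that gives a higher number than hydrogen beyond the scatter, with a 2.5-fold higher number from compound 1 to compound 4 (0.39 log units; beyond the scatter), and against methyl it gives a 13-fold higher number from compound 2 to compound 4 (1.11 log units; beyond the scatter), the largest step in this set. Nothing shown explains the difference between the two rings. On these data alone, what an ethyl group, or a longer chain carrying an amine, would give on this nitrogen stays open.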